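A sulfanyl group replaces amino on a compound at the limit

The source may report more compounds than this note shows. Statements on the series, on what has been measured and on what is new or still open speak of the compounds shown alone.

In a functional assay on CCRF-CEM cells (Homo sapiens) for cytotoxicity (a lower number here means a stronger inhibitor, a higher number a weaker inhibitor), compound 1 (`Cc1cn([C@@H]2C=C[C@H](CO)C2)c(=O)[nH]c1=O`) gives > 100000 nM, a limit of the assay. Compound 2 (`COC1O[C@H]2[C@H](COC(C)(C)C)C[C@H](n3cnc4c(Cl)ncnc43)[C@H]2O1`) gives > 100000 nM, again a limit. Compound 3 (`Nc1ncnc2c1ncn2[C@@H]1C=C[C@H](CO)C1`) gives > 100000 nM, also a limit and not a number. All the data so far therefore come down to the limit of > 100000 nM in this assay, at which 3 of the 3 values shown sit.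

Compound 4 (`OC[C@H]1C=C[C@@H](n2cnc3c(S)ncnc32)C1`) differs from compound 3 by sulfanyl in place of amino on an aromatic carbon, with sulfanyl in place of amino on an aromatic carbon. Among the measured compounds shown here, no measured pair shows what such a change does in this assay. A modest move towards stronger inhibition is expected, though with much uncertainty, and the expected step runs an at least 1.6-fold lower number from compound 3 to compound 4 (0.22 log units; that floor lies within the scatter). Compound 4 is estimated at 60000 nM, with an expected range of 8000 nM to 200000 nM.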

Compound 4, half-maximal inhibitory concentration: > 100000 nM
Compound 4 ended at the assay's limit (the forecaster's own chance of this, stated with the estimate: 50%); middle value at least 1.6-fold (0.22 log units) away from the limit.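

No step can be read between compound 3 and compound 4, since neither gives a number and both stop at a limit: the limit of > 100000 nM in this assay, at which 4 of the 4 values shown sit. The compounds shown leave open whether sulfanyl in place of amino changes anything in this assay.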